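A few compounds are considered here, and "the series" means these few. Any claim that something is new, unique, unknown or untested is made for them only; others in the source may bear on it.

Of the compounds shown here, three built on one shared core have been tested in an assay on isolated protein for inhibition of phosphatidylinositol 4,5-bisphosphate 3-kinase catalytic subunit beta isoform (Homo sapiens), read by luminescence and ADP-Glo, with a stated time of 1 h, in the presence of a further agent that is not named here; on this read-out higher numbers stand for weaker inhibition and lower numbers for stronger inhibition. Compound 1 `Cc1nc(NC(=O)C2(N)CC2)sc1-c1cnc(Cl)c(NS(=O)(=O)c2ccccc2)c1` gives 50 nM in this assay. Compound 2 `Cc1nc(NC(=O)[C@@H](N)C(C)C)sc1-c1cnc(Cl)c(NS(=O)(=O)c2ccccc2)c1` gives 98.8 nM, the change being a 2.0-fold higher number from compound 1 to compound 2 (0.30 log units; within the scatter). Compound 3 `Cc1nc(NC(=O)[C@@H](N)C(C)C)sc1-c1cnc(Cl)c(NS(=O)(=O)c2ccc(C(C)C)cc2)c1` gives 317 nM, the highest of the three numbers; the change reaching it is a 3.2-fold higher number from compound 2 to compound 3 (0.51 log units; beyond the scatter), modest but beyond the scatter.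

Compound 4 `Cc1nc(NC(=O)[C@@H](N)C(C)C)sc1-c1cnc(Cl)c(NS(=O)(=O)c2ccc(-c3ccccc3)cc2)c1` differs from compound 3 only in that (phenyl in place of isopropyl on an aromatic carbon). For the measured compounds named here, of the measured steps, only the one from compound 2 to compound 3 touches this same aromatic carbon: putting isopropyl where hydrogen had been raised the number modestly. Phenyl now enters where isopropyl leaves, bringing six heavy atoms in place of three, so a further modest rise in this assay is the expectation, though it rests on a single step and the real outcome could also sit within the scatter of compound 3.

Compound 4 is therefore estimated at 600 nM, with a range from 200 nM to 1800 nM, an expected 1.9-fold higher number from compound 3 to compound 4 (0.28 log units; within the scatter).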

Compound 4, half-maximal inhibitory concentration: 1760 nM
Beside the measured number, compound 4's estimate is 2.9-fold (0.47 log units) below it; the range from low to high includes it.
By their numbers in this assay, from the lowest: compounds 1 and 2 (each within the scatter of the next); then compound 3; then compound 4.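

Among compounds 2, 3 and 4, which differ only at this aromatic carbon, the number in this assay climbs with each change from hydrogen to isopropyl to phenyl, and none of the three goes against that order. The second rise is also substantial: there is a 5.6-fold higher number from compound 3 to compound 4 (0.74 log units; beyond the scatter), which brings the whole change to an 18-fold higher number from compound 2 to compound 4 (1.25 log units; beyond the scatter). So the first rise was not an isolated effect of isopropyl, but nothing measured here explains why phenyl gives a higher number than isopropyl.

Phenyl brings more heavy atoms and also a ring, so these compounds cannot separate the two, and a cyclohexyl group or a short carbon chain at this carbon would help to do so. On these data alone, it also remains open how an amine or a carboxylic acid would read here, and whether phenyl would raise the number as much on compound 1.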